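Changing One Aromatic Substituent: Compound 3 to Compound 4

The compounds below may be only part of what the source reports. "The series", "measured", "known", "first", "only" and "open" are said of these compounds alone.

Measured so far in a functional assay (aorta) with Rattus norvegicus as the target; on this read-out higher numbers stand for weaker inhibition and lower numbers for stronger inhibition:
compound 1 `CC1(C)Oc2ccc(C#N)cc2[C@@H](NC(=O)Nc2ccccc2)[C@@H]1O`: 800 nM
compound 2 `CC1(C)Oc2ccc(C#N)cc2[C@@H](n2cc(C#N)c3ccccc32)[C@@H]1O`: 2200 nM
compound 3 `CC1(C)Oc2ccc(C#N)cc2[C@@H](/N=C(\NC#N)Nc2ccc(C(F)(F)F)cc2)[C@@H]1O`: 8100 nM

Among these three, compound 3 gives the highest number in this assay, which on this read-out means the weakest inhibition. Its gap to compound 2, and the larger gap to compound 1, both lie beyond the usual scatter of repeated measurements.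

Compound 4 `CSc1ccc(N/C(=N/[C@@H]2c3cc(C#N)ccc3OC(C)(C)[C@H]2O)NC#N)cc1` has not yet been measured. It differs from compound 3 in a single place: methylsulfanyl in place of trifluoromethyl on an aromatic carbon. Going by the values given here, no measured pair of compounds shows this same change, so there is no earlier step to lean on. The expected step is a 1.2-fold lower number from compound 3 to compound 4 (0.10 log units; within the scatter), that is, none beyond the scatter in either direction. The estimated value for compound 4 in this assay is 6500 nM, with a range from 1800 nM to 24000 nM.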

Compound 4, half-maximal inhibitory concentration: 6300 nM
Beside the measured number, compound 4's estimate is 1.0-fold (0.01 log units) above it; the range from low to high includes it.
By their numbers in this assay, from the lowest: compound 1; then compound 2; then compounds 4 and 3 (each within the scatter of the next).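

In this assay, methylsulfanyl in place of trifluoromethyl gives a 1.3-fold lower number from compound 3 to compound 4 (0.11 log units; within the scatter). Going by these compounds alone, this is the first view of a change at this place, on an aromatic carbon para to a large group, and it shows that these two groups, which differ in their atoms and heavy-atom count, cannot be told apart in this read-out. No available measurement bears on why the two read alike. The compounds shown leave open whether an amine or a carboxylic acid at this same place would also read alike.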